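This account rests on a few compounds, and the source may have more. Where it says the series, first, only, none or still open, it means among the compounds named here.

Compound 1 `Cc1ccc(/C=N/NC(=O)CSc2nnnn2C)cc1` gives 3160000 nM in a functional assay on A549 cells (Homo sapiens) for cytotoxicity, read by XTT assay, with a stated time of 24 h; on this read-out higher numbers stand for weaker inhibition and lower numbers for stronger inhibition.
Compound 2 `Cn1nnnc1SCC(=O)N/N=C/c1ccccc1F` gives 9000000 nM in this assay.

Of the two measured compounds, compound 2 has the higher number in this assay, and its nearest neighbour, compound 1, lies beyond the usual scatter from it, so compound 2 is the weaker of the pair on this read-out. Compound 3 `Cn1nnnc1SCC(=O)N/N=C/c1ccccc1O` has not yet been measured. It differs from compound 2 in one place: hydroxy in place of fluoro on an aromatic carbon. Among the compounds with values here, no measured pair shows what such a change does in this assay, so the expectation for compound 3 rests on the value of compound 2 alone. A change of one heavy atom on the aromatic ring is expected to shift the number little, if at all, beyond the scatter; the expected step of a 1.5-fold lower number from compound 2 to compound 3 (0.18 log units; within the scatter) is therefore small and toward a slightly lower number. Compound 3 is estimated at 6000000 nM, with a range from 2000000 nM to 20000000 nM.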

Compound 3, half-maximal inhibitory concentration: > 10000000 nM
Compound 3: a limit, no number; the forecaster's own chance of this, stated with the estimate: 20%; middle value at least 1.6-fold (0.22 log units) from the limit.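

In this assay compound 3 gives > 10000000 nM, which is a limit and not a number. Hydroxy in place of fluoro on this aromatic carbon, ortho to a large group, is the only change shown at this position, and it reads as an at least 1.1-fold higher number from compound 2 to compound 3 (0.04 log units; that floor lies within the scatter), so the step has a floor but no known size, and it shows no move toward stronger inhibition. The read-out stops at this point: the limit of > 10000000 nM in this assay, at which 1 of the 3 values shown sits.

Going by these compounds, how far compound 3 actually lies from compound 2 stays open, since the limit gives no number for it. Also open, on these data alone, is how an amine or a methoxy group on the same aromatic carbon would read in this assay, and whether any group there could bring the number down.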